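Ester to methylisoxazole on the aminomethyl arm of compound 2

A few compounds are considered here, and "the series" means these few. Any claim that something is new, unique, unknown or untested is made for them only; others in the source may bear on it.

Measured so far:
- compound 1 `COC(=O)c1cc2ccccc2n1[C@@H]1c2cc(C#N)ccc2OC(C)(C)[C@H]1O` gives 33000 nM in a functional assay (aorta) with Rattus norvegicus as the target; a higher number here means a weaker inhibitor, a lower number a stronger inhibitor
- compound 2 `CCCCOC(=O)CN(c1ccccc1)[C@H]1c2cc(C#N)ccc2OC(C)(C)[C@@H]1O` gives 27000 nM in this assay

Compound 2 holds the lower of the two numbers in this assay, yet its gap to compound 1 lies within the scatter, so the two cannot be ranked. Compound 3 `Cc1cc(CN(c2ccccc2)[C@H]2c3cc(C#N)ccc3OC(C)(C)[C@@H]2O)on1` carries 3-methyl-1,2-oxazol-5-yl in place of butoxycarbonyl on a saturated chain carbon bound to a nitrogen on an aromatic ring. For the measured compounds named here, no measured pair shows what this exchange does, so only a modest step is expected from compound 2 to compound 3, probably none beyond the scatter, estimated as a 1.4-fold lower number from compound 2 to compound 3 (0.13 log units; within the scatter). For compound 3 the expected value in this assay is 20000 nM, within 6000 nM to 70000 nM.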

Compound 3, half-maximal inhibitory concentration: > 30000 nM
Compound 3: only a limit was reported; the forecaster's own chance of this, stated with the estimate: 15%; middle value at least 1.5-fold (0.17 log units) away from the limit.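

On a saturated chain carbon bound to a nitrogen on an aromatic ring, putting 3-methyl-1,2-oxazol-5-yl in place of butoxycarbonyl in this assay gives an at least 1.1-fold higher number from compound 2 to compound 3 (0.04 log units; that floor lies within the scatter). For the compounds shown here, this exchange therefore brings no lower number at this position, something the earlier compounds could not show. The reading for compound 3 is a limit of the assay and not a number: the limit of > 30000 nM in this assay, at which 1 of the 3 values shown sits.

From the compounds shown here alone, how far the true value of compound 3 lies from that limit stays open. So does whether a carboxylic acid or a primary amide at this place would give a lower number.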